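Compound 2 to compound 3: replacing the indolyl group

The compounds below may be only part of what the source reports. "The series", "measured", "known", "first", "only" and "open" are said of these compounds alone.

Measured in a functional assay on HeLa cells (Homo sapiens) for inhibition, read by CCK-8 assay, with a stated time of 48 h; on this read-out higher numbers stand for weaker inhibition and lower numbers for stronger inhibition:
- compound 1 `COc1cc(-c2ccnc3cc(-c4cccc(C)c4)nn23)cc(OC)c1OC`: 4230 nM
- compound 2 `COc1cc(-c2ccnc3cc(-c4ccc5ccn(C)c5c4)nn23)cc(OC)c1OC`: 187 nM

Of these two, compound 2 holds the lower number, at 187 nM. Compound 3 `COc1ccc(-c2cc3nccc(-c4cc(OC)c(OC)c(OC)c4)n3n2)cc1N` is not yet measured. It changes the same place on the shared core: 3-amino-4-methoxyphenyl in place of 1-methyl-1H-indol-6-yl on an aromatic carbon. Within the data shown here, only one measured step bears on this, a 23-fold lower number from compound 1 to compound 2 (1.35 log units; beyond the scatter), where 1-methyl-1H-indol-6-yl replaced 3-methylphenyl. That large step shows the number responds strongly to the group at this place. Compound 3 gives up the indolyl group and returns to a single six-membered aromatic ring of carbon only, as in compound 1 at 4230 nM. However, no measured compound carries its amino or methoxy substituents. Going by these compounds, the direction therefore stays open, and the expected result is a 1.1-fold higher number from compound 2 to compound 3 (0.03 log units; within the scatter). For compound 3 the estimate is 200 nM, with an expected range of 30 nM to 1300 nM.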

Compound 3, half-maximal inhibitory concentration: 283 nM
Compound 3: middle estimate off by 1.4-fold (0.15 log units), on the low side; the measured number falls inside the stated range.
By their numbers in this assay, from the lowest: compounds 2 and 3 (each within the scatter of the next); then compound 1.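

In this assay, a single six-membered aromatic ring of carbon only can take the place of the two-ring 1-methyl-1H-indol-6-yl group without a step beyond the scatter: a 1.5-fold higher number from compound 2 to compound 3 (0.18 log units; within the scatter). Having one such ring does not settle the number by itself, as compound 1 and compound 3 both have one, yet the change from 3-methylphenyl to 3-amino-4-methoxyphenyl gives a 15-fold lower number from compound 1 to compound 3 (1.17 log units; beyond the scatter). No supporting data are available to account for either step.

Whether the amino group, the methoxy group or the two together carry the large step stays open, as no compound shown has one without the other. Also open, going by these compounds, is how the number would respond to a hydroxyl or an acetamide in place of the amino group.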